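The source may report more compounds than this note shows. Statements on the series, on what has been measured and on what is new or still open speak of the compounds shown alone.

Series notes. Compound 1 `CCCn1cc(-c2cc(OCC[C@@H]3NC(=O)N(C)CCCC/C=C\[C@@H]4C[C@@]4(C(=O)NS(=O)(=O)C4(C)CC4)NC3=O)c3ccc(OC)c(C)c3n2)cn1` gives in an ADME assay on cells (Homo sapiens) for activation (on this read-out lower numbers stand for higher toxicity in this test and higher numbers for lower toxicity in this test), a half-maximal cytotoxic concentration of 62300 nM. For the measured compounds named here, compound 3 `CCn1cc(-c2cc(OCC[C@@H]3NC(=O)N(C)CCCC/C=C\[C@@H]4C[C@@]4(C(=O)NS(=O)(=O)C4(C)CC4)NC3=O)c3ccc(OC)c(C)c3n2)cn1` gives 36700 nM in this assay, and the step of a 1.7-fold lower number from compound 1 to compound 3 (0.23 log units; within the scatter) is the only measured step in the set. Compound 2 `COc1ccc2c(OCC[C@@H]3NC(=O)N(C)CCCC/C=C\[C@@H]4C[C@@]4(C(=O)NS(=O)(=O)C4(C#N)CC4)NC3=O)cc(-c3nc(C(C)C)cs3)nc2c1Cl` gives in this assay only a limit, > 75000 nM. Compound 2 thus stands at the limit of this test, as the limit of > 75000 nM in this assay, at which 1 of the 3 values shown sits, states, and no number places it against compound 1 or compound 3.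

Compound 4 `C#C[C@@H]1CCCN1S(=O)(=O)NC(=O)[C@@]12C[C@H]1/C=C\CCCCN(C)C(=O)N[C@@H](CCOc1cc(-c3nc(C(C)C)cs3)nc3c(Cl)c(OC)ccc13)C(=O)N2` has not yet been measured in this assay. It differs from compound 2 at one place: 2-ethynylpyrrolidin-1-yl in place of 1-cyanocyclopropyl on a sulfonyl sulfur. The entering group is a five-membered non-aromatic ring with 1 hetero atom and 1 defined stereocentre, where the leaving group was a three-membered ring of carbon only. Going by the values given here, none of the measured steps touches the sulfonyl sulfur; the single step, a 1.7-fold lower number from compound 1 to compound 3 (0.23 log units; within the scatter), lies elsewhere on the shared core and is within the scatter. No measured evidence supports a step in either direction for the change into compound 4, so the working expectation is for compound 4 a step of a number no higher from compound 2 to compound 4 (the limit leaves the size open) in this assay that is not beyond the scatter. Compound 2 itself stands at a limit. The estimate for compound 4 is therefore 75000 nM, with an expected range from 30000 nM to 150000 nM, and a fair chance that this assay again reports only a limit.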

Compound 4, half-maximal cytotoxic concentration: 21200 nM
Compound 4: the middle estimate sits 3.5-fold (0.55 log units) above what was measured; measured number below the stated range.
By their numbers in this assay, from the lowest: compounds 4, 3 and 1 (each within the scatter of the next, the first and the last beyond it). At a limit, above all of these: compound 2.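

In this assay, for the compounds shown here, 2-ethynylpyrrolidin-1-yl in place of 1-cyanocyclopropyl on a sulfonyl sulfur gives an at least 3.5-fold lower number from compound 2 to compound 4 (0.54 log units; beyond the scatter), the first step that lies beyond the scatter. On this read-out the lower number stands for higher toxicity in this test, so in this pair the group on the sulfonyl sulfur does bear on the result, which the earlier step elsewhere on the shared core did not show for any position. The full size of the step stays open, since compound 2 is held only as a limit: the limit of > 75000 nM in this assay, at which 1 of the 4 values shown sits.

This single pair does not separate the ring change from the change in the attached nitrile and ethynyl groups. From the compounds shown here alone, how a plain dimethylamino group or an unsubstituted piperidine on the sulfonyl sulfur would read in this assay, and whether the step carries over to the core of compound 1, remain open.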